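Hydroxy to methoxy on compound 1: expected read-out

The source may hold more compounds than are shown below. What is called first, only, known or untested is meant among the compounds shown, and "the series" means these compounds.

In a functional assay on HOP-62 cells (Homo sapiens) for inhibition, read by sulforhodamine B assay, with a stated time of 48 h, tested at 0.1 uM (on this read-out higher numbers stand for a weaker effect at the one concentration tested and lower numbers for a stronger effect), compound 1 `O=C(Nc1cccc(-n2cc(-c3ccncc3)c(-c3cc(O)cc(Cl)c3)n2)c1)Nc1ccc(Cl)c(C(F)(F)F)c1` gives 97%. Going by the values given here, compound 2 `O=C(Nc1cccc(-n2cc(-c3ccncc3)c(-c3cc(O)cc(Cl)c3)n2)c1)Nc1ccc(Cl)c(Cl)c1` gives 97% in this assay, and the one measured step, no change at the digits printed from compound 1 to compound 2 (within the scatter), was chloro in place of trifluoromethyl on an aromatic carbon. Compound 1 thus stands level with compound 2. Compound 3 `COc1cc(Cl)cc(-c2nn(-c3cccc(NC(=O)Nc4ccc(Cl)c(C(F)(F)F)c4)c3)cc2-c2ccncc2)c1` differs from compound 1 by methyl in place of hydrogen on an oxygen on an aromatic ring, that is hydroxy to methoxy. Among the compounds with values here, no measured step touches this oxygen; the single step at hand only shows the read-out unmoved by a remote change. Compound 3 is therefore expected to stay near compound 1, with the expected step of a number 2 percentage points lower from compound 1 to compound 3 (within the scatter) within the scatter. The estimate for compound 3 is 95%, range 80% to 105%.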

Compound 3, a percentage reported as activity, at one concentration (the size of the read-out at that concentration, not a potency): 104%
Compound 3: the middle estimate sits 9 percentage points below what was measured, within the range that was stated.
By their numbers in this assay, from the lowest: compounds 1, 2 and 3 (each within the scatter of the next).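

In this assay, hydroxy to methoxy gives a number 7 percentage points higher from compound 1 to compound 3 (within the scatter) on the core of compound 1. Going by these compounds alone, this is the first reading at this oxygen, since the earlier step concerned only chloro in place of trifluoromethyl, and methyl in place of hydrogen here leaves the read-out within the scatter. Nothing measured here explains this result. Open, from the compounds shown here alone, is whether an amine or a longer chain such as ethoxy in place of hydroxy would move the read-out beyond the scatter. Also open, going by these compounds, is whether the flat picture holds at other concentrations.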